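The compounds below may be only part of what the source reports. "The series", "measured", "known", "first", "only" and "open" are said of these compounds alone.

Three measured compounds anchor the series. Compound 1 `CC(=O)OC[C@H]1O[C@@H](n2cc(-c3cn(Cc4ccc(C(C)(C)C)cc4)nn3)c(=O)[nH]c2=O)C[C@@H]1OC(C)=O` gives 90.4% in a functional assay on PC-3 cells (Homo sapiens) for cytotoxicity, read by sulforhodamine B assay, tested at 10 uM (a higher number here means more inhibition at the concentration tested (going by the name of the read-out), a lower number less inhibition), compound 2 `O=c1[nH]c(=O)n([C@H]2C[C@H](O)[C@@H](CO)O2)cc1-c1cn(Cc2ccccc2)nn1` gives 92.1% in this assay, and compound 3 `CC(=O)OC[C@H]1O[C@@H](n2cc(-c3cc(C)no3)c(=O)[nH]c2=O)C[C@@H]1OC(C)=O` gives 92.4% in this assay. Compound 3 holds the highest of the three numbers, yet both compound 2 and compound 1 sit within the scatter of it, so the three cannot be ranked. Compound 4 `CC(=O)OC[C@H]1O[C@@H](n2cc(-c3cc(-c4ccc(C(C)C)cc4)no3)c(=O)[nH]c2=O)C[C@@H]1OC(C)=O` has not been measured. It differs from compound 3 by 4-isopropylphenyl in place of methyl on an aromatic carbon. All three measured numbers lie close together and level, and on that basis no step beyond the scatter is expected: the step of a number 2.4 percentage points lower from compound 3 to compound 4 (within the scatter) is expected to be small. Compound 4 is therefore estimated at 90%, within a range from 76% to 98%.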

Compound 4, a percentage reported as inhibition, at one concentration (the size of the read-out at that concentration, not a potency): 50.3%
Compound 4: the middle estimate sits 39.7 percentage points above what was measured; the measured number lies below the stated range.
By their numbers in this assay, from the lowest: compound 4; then compounds 1, 2 and 3 (each within the scatter of the next).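

In this assay, going by these compounds alone, 4-isopropylphenyl in place of methyl on the aromatic carbon next to the ring nitrogen gives a number 42.1 percentage points lower from compound 3 to compound 4 (beyond the scatter) and is the first step beyond the scatter. This position is therefore not indifferent to what it carries, which the three level numbers could not show. Nothing available accounts for this drop.

The compounds shown leave open whether the aromatic ring or the isopropyl group goes with the lower number. Plain phenyl, ethyl or an amine at this carbon would begin to separate these possibilities.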